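Methylating a Phenol in an Aromatase Inhibitor Series

The source may hold more compounds than are shown below. What is called first, only, known or untested is meant among the compounds shown, and "the series" means these compounds.

Compound 1 `COc1ccc(/C=C/C(O)c2ccccc2O)cc1CC=C(C)C` is tested in an assay on isolated protein for inhibition of Aromatase (Homo sapiens) (a higher number here means a weaker inhibitor, a lower number a stronger inhibitor), and its result for compound 1 of > 310000 nM is a limit of the assay, not a number. Within the data shown here, compound 2 `COc1ccc(C2CC(=O)c3ccc(O)cc3O2)cc1CC=C(C)C` gives 4080 nM in this assay, the only number among the values shown. The remaining value shown is the limit of > 310000 nM in this assay, at which 1 of the 2 values shown sits. Compound 3 `COc1ccc2c(c1)OC(c1ccc(OC)c(CC=C(C)C)c1)CC2=O` differs from compound 2 by methyl in place of hydrogen on an oxygen on an aromatic ring. Among the measured compounds shown here, no measured pair shows this kind of step, and a modest weakening beyond the scatter is expected. For compound 3 the expected step of a 2.0-fold higher number from compound 2 to compound 3 (0.29 log units; within the scatter) leads to an estimate of 8000 nM, with a range from 2000 nM to 35000 nM.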

Compound 3, half-maximal inhibitory concentration: 3670 nM
Beside the measured number, compound 3's estimate is 2.2-fold (0.34 log units) above it; low and high end bracket the measured number.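

Changing hydroxy to methoxy on this oxygen on an aromatic ring gives a 1.1-fold lower number from compound 2 to compound 3 (0.05 log units; within the scatter) in this assay. Among these compounds, this is the first measured step at this position, and it shows that in this assay, the hydrogen on this oxygen can give way to methyl with the result staying within the usual scatter. Nothing measured here explains why the number holds. Still open, from the compounds shown here alone, is whether a longer chain on this oxygen, such as propyl, would also stay within the scatter, or whether an amine in place of the hydroxy would.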